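The compounds below may be only part of what the source reports. "The series", "measured", "known", "first", "only" and "open" are said of these compounds alone.

Measured so far in an ADME assay on HEK293 cells (Homo sapiens) for cytotoxicity, read by MTT assay, with a stated time of 48 h; on this read-out lower numbers stand for stronger inhibition and higher numbers for weaker inhibition:
- compound 1 `CCS(=O)(=O)Nc1ccc(NC(=O)c2cccc(C(F)(F)F)c2)cc1OC`; compound 1 gives > 250000 nM, a limit of the assay and not a number.
- compound 2 `CCS(=O)(=O)Nc1ccc(NC(=O)c2cc(C(F)(F)F)cc(C(F)(F)F)c2)cc1OC`; compound 2 gives > 250000 nM, likewise a limit.
- compound 3 `CS(=O)(=O)Nc1ccc(NC(=O)c2cccc(C(F)(F)F)c2)cc1F`; compound 3 gives > 250000 nM, again a limit.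

From compound 1 to compound 2 the change is trifluoromethyl in place of hydrogen on an aromatic carbon. The step it made, a step that the two limits leave unreadable from compound 1 to compound 2, cannot be sized because of the limit of > 250000 nM in this assay, at which 3 of the 3 values shown sit, so no direction or magnitude is read from it.

Compound 4 `CS(=O)(=O)Nc1ccc(NC(=O)c2cc(C(F)(F)F)cc(C(F)(F)F)c2)cc1F` is not yet measured in this assay. It differs from compound 3 by trifluoromethyl in place of hydrogen on an aromatic carbon, the same change in the same surroundings as between compound 1 and compound 2. How the core of compound 3 differs from the core of compound 1 is not broken down here.

The step from compound 3 to compound 4 in this assay is expected to be a number no higher from compound 3 to compound 4 (the limit leaves the size open), resting on the unreadable step that the two limits leave unreadable from compound 1 to compound 2 and on (the limit of > 250000 nM in this assay, at which 3 of the 3 values shown sit). Compound 4 is therefore estimated at 250000 nM in this assay, most likely reported again as a limit.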

Compound 4, half-maximal inhibitory concentration: > 250000 nM
Compound 4 ended at the assay's limit; the forecaster's own chance of this, stated with the estimate: 85%; the middle value lies on the limit itself.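

No step can be read from compound 3 to compound 4 in this assay, because both values are limits and not numbers: the limit of > 250000 nM in this assay, at which 4 of the 4 values shown sit.

The compounds shown leave open whether the added trifluoromethyl changes cytotoxicity at all, since no compound gives a number.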